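Variation on the amide nitrogen of a shared core

This account rests on a few compounds, and the source may have more. Where it says the series, first, only, none or still open, it means among the compounds named here.

Measured so far in an assay on isolated protein for inhibition of glutathione S-transferase Mu 2 (Homo sapiens), with a stated time of 10 min; on this read-out higher numbers stand for weaker inhibition and lower numbers for stronger inhibition:
- compound 1 `O=C(O)CCC(=O)OCCCCCCSc1ccc([N+](=O)[O-])c2nonc12` gives 160 nM
- compound 2 `O=C(CCC(=O)OCCCCCCSc1ccc([N+](=O)[O-])c2nonc12)Nc1ccccc1F` gives 350 nM
- compound 3 `O=C(CCC(=O)OCCCCCCSc1ccc([N+](=O)[O-])c2nonc12)Nc1ccc(C(F)(F)F)cc1` gives 90 nM

Compound 3 gives the lowest of the three numbers in this assay, but its gap to compound 1 is within the scatter; only compound 2 sits clearly apart from it. The next compound, compound 4 `CCN(CC)CCCNC(=O)CCC(=O)OCCCCCCSc1ccc([N+](=O)[O-])c2nonc12`, differs from compound 3 by 3-(diethylamino)propyl in place of 4-(trifluoromethyl)phenyl on an amide-type nitrogen. All measured steps concern this same position: a 2.2-fold higher number from compound 1 to compound 2 (0.34 log units; beyond the scatter) and a 1.8-fold lower number from compound 1 to compound 3 (0.25 log units; within the scatter) show that replacing hydroxy with (2-fluorophenyl)amino or (4-(trifluoromethyl)phenyl)amino moves the number only modestly, in opposite directions, and a 3.9-fold lower number from compound 2 to compound 3 (0.59 log units; beyond the scatter) shows that exchanging one aryl for another gives a modest step. Nothing measured exchanges an aryl for a 3-(diethylamino)propyl chain, so the direction cannot be read from the steps; their size suggests a modest change at most, more likely upward than downward given that compound 3 holds the lowest number. On that basis the expected step is a 2.2-fold higher number from compound 3 to compound 4 (0.35 log units; beyond the scatter). The estimate for compound 4 is 200 nM, with a range from 70 nM to 600 nM.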

Compound 4, half-maximal inhibitory concentration: 440 nM
Compound 4: the middle estimate sits 2.2-fold (0.34 log units) below what was measured; measured number inside the range.
By their numbers in this assay, from the lowest: compounds 3 and 1 (each within the scatter of the next); then compounds 2 and 4 (each within the scatter of the next).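

In this assay, replacing the aryl with the ring-free 3-(diethylamino)propyl chain gives a 4.9-fold higher number from compound 3 to compound 4 (0.69 log units; beyond the scatter) on the amide-type nitrogen, so this position responds to a change of group type as well as to an exchange of one aryl for another. The same chain gives a 1.3-fold higher number from compound 2 to compound 4 (0.10 log units; within the scatter) against the 2-fluorophenyl amide, a gap within the scatter, so an aryl on this nitrogen is not needed for a number in that range. Set against the free acid, the chain gives a 2.8-fold higher number from compound 1 to compound 4 (0.44 log units; beyond the scatter) with the hydroxy replaced, and compound 3 remains the only amide shown that is not clearly above compound 1. No measurement shown bears on the reason for these differences.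

Open, going by these compounds, is whether the amine nitrogen or the chain itself sets the number for compound 4, which a plain alkyl chain of similar length or a shorter amine chain would address. An unsubstituted phenyl amide would likewise separate the role of the trifluoromethyl group from that of the aryl ring.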